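Swapping the Sulfonamide Group on a Shared Core

The compounds below may be only part of what the source reports. "The series", "measured", "known", "first", "only" and "open" are said of these compounds alone.

Two measured compounds share one core and differ only in the group carried on an amine nitrogen. Compound 1 `CCCCc1ccc(CNCc2ccccc2)c(=O)n1Cc1ccc(-c2ccccc2-c2nn[nH]n2)cc1` has a benzyl there, and in a functional assay (aorta) for antagonist activity, with Oryctolagus cuniculus as the target (a lower number here means a stronger inhibitor, a higher number a weaker inhibitor), compound 1 gives 1 nM. Compound 2 `CCCCc1ccc(CNS(=O)(=O)c2ccc(C)cc2)c(=O)n1Cc1ccc(-c2ccccc2-c2nn[nH]n2)cc1` carries a (4-methylphenyl)sulfonyl instead, and in this assay compound 2 gives 9 nM. Going by the values given here, the step of a 9.0-fold higher number from compound 1 to compound 2 (0.95 log units; beyond the scatter) is the only measured step, and it leaves compound 2 with the highest number of the two, the weaker inhibitor of the pair.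

Compound 3 `CCCCc1ccc(CN(C(C)C)S(C)(=O)=O)c(=O)n1Cc1ccc(-c2ccccc2-c2nn[nH]n2)cc1` is not yet measured. It differs from compound 2 in one place: isopropyl(methylsulfonyl)amino in place of ((4-methylphenyl)sulfonyl)amino on a saturated chain carbon bound to an aromatic carbon. Among the compounds with values here, no measured step covers a change of this kind; the one known step swapped a benzyl for a sulfonyl group rather than altering the sulfonyl group itself, so it gives only a loose sense of how far such a change can move the number. Here the sulfonyl stays, the aromatic ring and the hydrogen-bond donor leave, and an isopropyl enters. On this basis compound 3 is expected to stay close to compound 2, with the step of a 1.7-fold higher number from compound 2 to compound 3 (0.22 log units; within the scatter) expected to fall within or only just beyond the scatter. The estimate for compound 3 in this assay is 15 nM, with a range from 4 nM to 60 nM.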

Compound 3, half-maximal inhibitory concentration: 0.9 nM
Estimate against measurement, compound 3: 17-fold (1.22 log units) above; the measured number lies below the stated range.
By their numbers in this assay, from the lowest: compounds 3 and 1 (each within the scatter of the next); then compound 2.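

In this assay, the result shows that a sulfonyl group on this nitrogen does not by itself set the weaker number of compound 2: with a 10-fold lower number from compound 2 to compound 3 (1.00 log units; beyond the scatter), the isopropyl(methylsulfonyl)amino group gives a change beyond the scatter even though the sulfonyl stays in place. With a 1.1-fold lower number from compound 1 to compound 3 (0.05 log units; within the scatter), the gap lies within the scatter, so this assay does not separate the benzylamino group of compound 1 from the group in compound 3. The change to compound 3 removes an aromatic ring and a hydrogen-bond donor and adds an isopropyl all at once, and no supporting measurement shows which of these differences accounts for the step.

The compounds shown leave open which part of the change matters: a plain methylsulfonylamino group, or the ((4-methylphenyl)sulfonyl)amino group with an isopropyl on its nitrogen, could help pull these parts apart. They also leave open how other groups on that nitrogen would behave, such as an ethyl or a tert-butyl in place of the isopropyl.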